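The compounds below may be only part of what the source reports. "The series", "measured", "known", "first", "only" and "open" are said of these compounds alone.

Compound 1 `Cn1c2cnc1OCCCCCCCCOc1cc(F)ccc1-2`: 46000 nM
Compound 2 `CCCCCCOc1ncc(-c2ccccc2OC)n1C`: 33000 nM

Both values come from a functional assay on PC-3 cells (Homo sapiens) for inhibition, read by colorimetric assay and MTT assay, with a stated time of 72 h (a lower number here means a stronger inhibitor, a higher number a weaker inhibitor), and lie within the scatter of each other, so compound 2 stands level with compound 1. Compound 3 `COc1ccccc1-c1cnc(OCCCc2ccccc2)n1C` has not yet been measured. It differs from compound 2 at the end of the chain: phenyl in place of propyl on a saturated chain carbon, three bonds along the chain from an oxygen on an aromatic ring, with phenyl in place of propyl on a saturated chain carbon, three bonds along the chain from an oxygen on an aromatic ring. Among the measured compounds shown here, no measured pair shows this change, so no step beyond the scatter is expected in this assay. The expected step is small: a 1.1-fold lower number from compound 2 to compound 3 (0.04 log units; within the scatter). For compound 3 the estimated value is 30000 nM, with an expected range of 12000 nM to 70000 nM.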

Compound 3, half-maximal inhibitory concentration: 27000 nM
Compound 3: middle estimate off by 1.1-fold (0.05 log units), on the high side; the range from low to high includes it.
By their numbers in this assay, from the lowest: compounds 3, 2 and 1 (each within the scatter of the next).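

Swapping propyl for phenyl on a saturated chain carbon, three bonds along the chain from an oxygen on an aromatic ring, gives a 1.2-fold lower number from compound 2 to compound 3 (0.09 log units; within the scatter) in this assay. At this position, then, a six-membered aromatic ring of carbon only can replace the propyl without a step beyond the scatter. Nothing available explains this result.

As far as these compounds go, it remains open whether an amine or a carboxylic acid at this chain end would produce a step beyond the scatter. The same is true of a longer chain.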